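This account rests on a few compounds, and the source may have more. Where it says the series, first, only, none or still open, it means among the compounds named here.

Measured compounds:
- compound 1, `COc1cc2nc(N3CCC(C(=O)NCC4CC4)CC3)nc(N)c2cc1OC`: 0.9 nM
- compound 2, `CCN(CC)C(=O)C1CCN(c2nc(N)c3cc(OC)c(OC)cc3n2)CC1`: 1.11 nM
- compound 3, `COc1cc2nc(N3CCC(C(=O)NCc4ccccc4)CC3)nc(N)c2cc1OC`: 0.22 nM

In an assay on isolated protein for displacement of a labelled ligand from Adrenergic receptor alpha-1 (Rattus norvegicus) (on this read-out higher numbers stand for weaker inhibition and lower numbers for stronger inhibition), compound 1 gives 0.9 nM, the second highest of the three numbers; compound 2 sits within the scatter of it (a 1.2-fold higher number from compound 1 to compound 2 (0.09 log units; within the scatter)), while compound 3 lies further away (a 4.1-fold lower number from compound 1 to compound 3 (0.61 log units; beyond the scatter)). Compound 4, `COc1cc2nc(N3CCC(C(=O)NCCOc4ccccc4)CC3)nc(N)c2cc1OC`, has not been measured. It differs from compound 1 by phenoxymethyl in place of cyclopropyl on a saturated chain carbon bound to an amide-type nitrogen. The step that bears on it most directly is the one in which a phenyl ring entered at the same place, a 4.1-fold lower number from compound 1 to compound 3 (0.61 log units; beyond the scatter), with a 5.0-fold lower number from compound 2 to compound 3 (0.70 log units; beyond the scatter) pointing the same way. In compound 4 the ring enters through a phenoxymethyl group rather than directly, so the account expects a lowering of the number beyond the scatter, but a smaller one than that seen for compound 3. The estimated step for compound 4 is therefore a 2.3-fold lower number from compound 1 to compound 4 (0.35 log units; beyond the scatter). Compound 4 is expected to give 0.4 nM in this assay, within a range from 0.15 nM to 1.2 nM.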

Compound 4, inhibition constant: 0.42 nM
Compound 4: the middle estimate sits 1.1-fold (0.02 log units) below what was measured; measured number inside the range.
By their numbers in this assay, from the lowest: compounds 3 and 4 (each within the scatter of the next); then compounds 1 and 2 (each within the scatter of the next).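

In this assay the new result shows that phenyl need not be attached directly at this place, on a saturated chain carbon bound to an amide-type nitrogen: phenoxymethyl in place of cyclopropyl also gives a 2.1-fold lower number from compound 1 to compound 4 (0.33 log units; beyond the scatter), and the (2-phenoxyethyl)amino amide compares with the diethylamino amide as a 2.6-fold lower number from compound 2 to compound 4 (0.42 log units; beyond the scatter). Phenoxymethyl in place of phenyl gives a 1.9-fold higher number from compound 3 to compound 4 (0.28 log units; within the scatter), so the two groups cannot be told apart here, and the larger group with its oxygen costs nothing beyond the scatter. The data offer no explanation for these steps.

On these data alone, how a 3-phenylpropyl group, with a carbon in place of the ether oxygen, would compare with 2-phenoxyethyl at this place remains open. Also open, as far as these compounds go, is whether an amine or a carboxylic acid on the phenyl ring of the 2-phenoxyethyl group would keep the number this low.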